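The source may hold more compounds than are shown below. What is called first, only, known or untested is meant among the compounds shown, and "the series" means these compounds.

Measured compounds in a functional assay (trachea) with Cavia porcellus as the target; on this read-out lower numbers stand for stronger inhibition and higher numbers for weaker inhibition:
- compound 1 `CCCCn1nc(-c2cccnc2)c2ccccc2c1=O` gives 2290 nM
- compound 2 `CCCCCCCCn1nc(-c2cccnc2)c2ccccc2c1=O` gives 21900 nM
- compound 3 `O=c1c2ccccc2c(-c2cccnc2)nn1CCSc1ccccc1` gives 9120 nM

Compound 1 stands lowest of the three numbers. Both measured steps away from it raise the number: a 9.6-fold higher number from compound 1 to compound 2 (0.98 log units; beyond the scatter) and a 4.0-fold higher number from compound 1 to compound 3 (0.60 log units; beyond the scatter). Between the other two, a 2.4-fold lower number from compound 2 to compound 3 (0.38 log units; beyond the scatter). In each of the two steps from compound 1 a larger group entered on the chain carried by the aromatic nitrogen of the shared core, and in each the number rose.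

Compound 4 `O=c1c2ccccc2c(-c2cccnc2)nn1CCO` differs from compound 1 by hydroxy in place of ethyl on a saturated chain carbon, two bonds along the chain from an aromatic nitrogen. Going by the values given here, no measured step puts a hydroxy at this position, so the bearing of the known steps is indirect. The two steps from compound 1 show that this chain position tolerates change only with a loss; here the group entering is smaller than the ethyl it replaces, which neither step covers. Given that both measured changes from compound 1 weakened inhibition, a modest rise in the number is expected, and the step of a 2.0-fold higher number from compound 1 to compound 4 (0.29 log units; within the scatter) is estimated with wide uncertainty. Compound 4 is expected to give about 4500 nM in this assay, in the range 1200 nM to 17000 nM.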

Compound 4, half-maximal inhibitory concentration: 4570 nM
Compound 4: middle estimate off by 1.0-fold (0.01 log units), on the low side; the measured number falls inside the stated range.
By their numbers in this assay, from the lowest: compounds 1, 4 and 3 (each within the scatter of the next, the first and the last beyond it); then compound 2.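

Hydroxy in place of ethyl on this chain carbon gives a 2.0-fold higher number from compound 1 to compound 4 (0.30 log units; within the scatter) in this assay, making it the first change at this position that stays within the scatter, whereas the phenylsulfanyl and longer alkyl changes both lie beyond it. The same hydroxy chain end also gives a 2.0-fold lower number from compound 3 to compound 4 (0.30 log units; within the scatter), so the two chain ends cannot be told apart here, while a 4.8-fold lower number from compound 2 to compound 4 (0.68 log units; beyond the scatter) is beyond the scatter and marks the long alkyl chain as the only one that hydroxy clearly separates from. This position therefore accepts an end group carrying a hydrogen-bond donor and acceptor without a loss that can be read, but no evidence is available on why the changes at this position give these numbers.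

Open, as far as these compounds go, is whether an amine, a carboxylic acid or a methyl ether at the same chain carbon would stay within the scatter as hydroxy does. Also open, from the compounds shown here alone, is whether hydroxy holds that place on a longer chain, such as a hydroxybutyl group, or whether chain length alone then sets the number.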